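The source may report more compounds than this note shows. Statements on the series, on what has been measured and on what is new or still open speak of the compounds shown alone.

Compound 3 `COC(=O)c1cc(-c2cccc(NC(=O)c3ccc(/C=C/C(=O)c4ccccc4C)cc3)c2)on1` carries a 2-methylphenyl on a carbonyl carbon. In an ADME assay on Vero cells (Chlorocebus sabaeus) for cytotoxicity, read by MTT assay, with a stated time of 72 h (on this read-out higher numbers stand for lower toxicity in this test and lower numbers for higher toxicity in this test), compound 3 gives > 25 ug/mL, and that figure is a limit of the assay rather than a number. Compound 2 `COC(=O)c1cc(-c2cccc(NC(=O)c3ccc(/C=C/C(=O)c4ccc(CC(C)C)cc4)cc3)c2)on1` has a 4-isobutylphenyl in that place; in this assay compound 2 gives > 10 ug/mL, again only a limit. The step that the two limits leave unreadable from compound 2 to compound 3 is therefore of unknown size. Compound 1 `COC(=O)c1cc(-c2cccc(NC(=O)c3ccc(/C=C/C(=O)c4cccnc4)cc3)c2)on1` stands at "not determined" (no result reported) in this assay. Compound 4 `COC(=O)c1cc(-c2cccc(NC(=O)c3ccc(/C=C/C(=O)c4ccccc4Br)cc3)c2)on1` differs from compound 3 by bromo in place of methyl on an aromatic carbon. No readable measured step bears on this change, so no shift beyond the scatter is expected, and the step that the limit leaves unreadable from compound 3 to compound 4 is estimated as small. Compound 4 is thus expected to give about 30 ug/mL in this assay, within 12 ug/mL to 80 ug/mL.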

Compound 4, half-maximal cytotoxic concentration: > 40 ug/mL
Compound 4 ended at the assay's limit; the forecaster's own chance of this, stated with the estimate: 70%; middle value at least 1.3-fold (0.12 log units) from the limit.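

Among the compounds shown here, the results for compound 2, compound 3 and compound 4 in this assay are all limits, not numbers, and no step among them can be read. The compounds shown leave open whether bromo in place of methyl changes the toxicity at all.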